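A few compounds are considered here, and "the series" means these few. Any claim that something is new, unique, unknown or untested is made for them only; others in the source may bear on it.

Values in a physicochemical assay for solubility, in phosphate buffer, with a stated time of 18 h; on this read-out higher numbers stand for higher solubility and lower numbers for lower solubility:
compound 1 `CC(C)(C)c1nc(CCCCCC#N)c2c(N)c(C#N)c(N)nc2n1`: 6000 nM
compound 2 `CC(C)(C)c1nc(-c2nccs2)c2c(N)c(C#N)c(N)nc2n1`: < 1500 nM (a limit of the assay, not a number)
compound 3 `CC(C)(C)c1nc(-c2ccsc2)c2c(N)c(C#N)c(N)nc2n1`: 40000 nM

Compound 3 has the highest value in the series, and the nearest number belongs to compound 1, with a 6.7-fold higher number from compound 1 to compound 3 (0.82 log units; beyond the scatter). Compound 2 sits at the limit of < 1500 nM in this assay, at which 1 of the 3 values shown sits.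

The next compound is compound 4 `CC(C)(C)c1nc(-c2ccncc2)c2c(N)c(C#N)c(N)nc2n1`, which has pyridin-4-yl in place of thiophen-3-yl on an aromatic carbon.

All three measured steps change this same place. Within the data shown here, the closest precedent is the exchange of one aromatic ring for another, an at least 26-fold higher number from compound 2 to compound 3 (1.42 log units; beyond the scatter), which is large. The two steps from the 5-cyanopentyl compound run in opposite directions, an at least 4.0-fold lower number from compound 1 to compound 2 (0.60 log units; beyond the scatter) and a 6.7-fold higher number from compound 1 to compound 3 (0.82 log units; beyond the scatter), so an aromatic ring at this place does not fix the direction. Among the measured compounds shown here, no measured compound has a six-membered ring here.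

Compound 3 already stands at the top with 40000 nM, so a modest fall is the more likely outcome, though a large move either way remains possible. The expected change is a 2.7-fold lower number from compound 3 to compound 4 (0.43 log units; beyond the scatter). For compound 4 the estimated value is 15000 nM, with an expected range of 2500 nM to 70000 nM.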

Compound 4, solubility: 44000 nM
For compound 4 the middle estimate is 2.9-fold (0.47 log units) below the measured one; the measured number falls inside the stated range.
By their numbers in this assay, from the lowest: compound 1; then compounds 3 and 4 (each within the scatter of the next). At a limit, below all of these: compound 2.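

In this assay, a six-membered ring at this place cannot be told apart from a five-membered one, a 1.1-fold higher number from compound 3 to compound 4 (0.04 log units; within the scatter), and the 5-cyanopentyl compound now stands clearly apart from a second aromatic ring, a 7.3-fold higher number from compound 1 to compound 4 (0.87 log units; beyond the scatter). The high level in this series is therefore not tied to thiophen-3-yl, to sulfur or to one ring size, and 1,3-thiazol-2-yl is the aromatic ring that goes against any general rule for aromatic rings here, an at least 29-fold higher number from compound 2 to compound 4 (1.46 log units; beyond the scatter). The value of compound 2 is a limit of the assay and not a number: the limit of < 1500 nM in this assay, at which 1 of the 4 values shown sits.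

Still open, as far as these compounds go, is whether the place of the ring nitrogen matters, as pyridin-2-yl or pyridin-3-yl would show, and whether a plain phenyl group would fall with compound 3 and compound 4 or with compound 2. Also open, from the compounds shown here alone, is what sets 1,3-thiazol-2-yl apart from the other two rings, a question that 1,3-thiazol-5-yl or an imidazole ring could help to narrow, and how a shorter chain ending in a nitrile or a carboxylic acid would compare with the 5-cyanopentyl chain.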